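This account rests on a few compounds, and the source may have more. Where it says the series, first, only, none or still open, it means among the compounds named here.

Compound 1 `CN(C)c1ccc(/C=C/c2c(F)cccc2Cl)cn1` carries a dimethylamino group on its core. In a functional assay on LS174T cells (Homo sapiens) for antiproliferative activity (on this read-out higher numbers stand for weaker inhibition and lower numbers for stronger inhibition), compound 1 gives 4.7 nM. Compound 2 `CNc1ccc(/C=C/c2c(F)cccc2Cl)cn1` differs from it by one change only, (hydrogen in place of methyl on a nitrogen on an aromatic ring), and in this assay compound 2 gives 4 nM. The step of a 1.2-fold lower number from compound 1 to compound 2 (0.07 log units; within the scatter) shows that this change leaves the inhibition essentially where it was. Compound 3 `CN(C)c1ncc(/C=C/c2c(Cl)cccc2Cl)cn1` is built on a different core from compound 1, and the difference between the two cores is not broken down here. In this assay compound 3 gives only a limit, > 200 nM; this is the limit of > 200 nM in this assay, at which 1 of the 3 values shown sits. Compound 4 `CNc1ncc(/C=C/c2c(Cl)cccc2Cl)cn1` is made from compound 3 by the same change as that from compound 1 to compound 2, namely (hydrogen in place of methyl on a nitrogen on an aromatic ring). Because that change gave a 1.2-fold lower number from compound 1 to compound 2 (0.07 log units; within the scatter), for compound 4 a similar small step is expected, a step that the limit leaves unreadable from compound 3 to compound 4. Compound 4 is therefore expected to give about 300 nM, most likely somewhere between 120 nM and 800 nM, and quite possibly only a limit again.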

Compound 4, half-maximal inhibitory concentration: > 200 nM
Compound 4 ended at the assay's limit; the forecaster's own chance of this, stated with the estimate: 65%; the middle value is on the limit's open side.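

Compound 3 and compound 4 both sit at a limit of the assay rather than at a number, so no step can be read between them: the limit of > 200 nM in this assay, at which 2 of the 4 values shown sit. The compounds shown leave open whether going from dimethylamino to methylamino on the core of compound 3 changes the inhibition at all, as it barely did on the core of compound 1.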